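Removing a Methoxy Group: Expected Effect on Cell Activity

A few compounds are considered here, and "the series" means these few. Any claim that something is new, unique, unknown or untested is made for them only; others in the source may bear on it.

Measured compounds:
compound 1, `COc1cc(-c2cc(/C=C/C(=O)c3ccc(N)cc3)[nH]n2)cc(OC)c1OC`: 100%
compound 2, `COc1ccc(-c2cc(/C=C/C(=O)c3ccc(N)cc3)[nH]n2)cc1OC`: 100%
compound 3, `COc1cc(C(=O)/C=C/c2cc(-c3cc(OC)c(OC)c(OC)c3)n[nH]2)cc(OC)c1OC`: 99%

All three were tested in a functional assay on IGROV-1 cells (Homo sapiens) for cytotoxicity, read by sulforhodamine B assay, with a stated time of 48 h, tested at 1 uM; on this read-out lower numbers stand for a stronger effect and higher numbers for a weaker effect at the one concentration tested. Compound 1 gives 100%, compound 2 gives 100% and compound 3 gives 99%; these three numbers lie within the scatter of one another.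

Compound 2 differs from compound 1 in one place, (hydrogen in place of methoxy on an aromatic carbon). The step of no change at the digits printed from compound 1 to compound 2 (within the scatter) shows no shift in the read-out. Compound 4, `COc1ccc(-c2cc(/C=C/C(=O)c3cc(OC)c(OC)c(OC)c3)[nH]n2)cc1OC`, not yet measured, stands to compound 3 exactly as compound 2 stands to compound 1: hydrogen in place of methoxy on an aromatic carbon. The surroundings of the place of change are the same in both pairs, so this is the same change. How the core of compound 3 differs from the core of compound 1 is not broken down here.

Because no change at the digits printed from compound 1 to compound 2 (within the scatter) shows no change, the step from compound 3 to compound 4 is expected to be about no change at the digits printed from compound 3 to compound 4 (within the scatter) in this assay . Compound 4 is therefore estimated at 99%, expected to fall between 88% and 105%.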

Compound 4, a percentage reported as activity, at one concentration (the size of the read-out at that concentration, not a potency): 93%
Estimate against measurement, compound 4: 6 percentage points above, and the stated range covers the measured number.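

In this assay, hydrogen in place of methoxy on an aromatic carbon gives a number 6 percentage points lower from compound 3 to compound 4 (within the scatter). Set beside the earlier step, the same change reads alike on the two cores, with no gap that stands out from the scatter: the same change on two cores in this assay, no change at the digits printed (within the scatter) from compound 1 to compound 2 and a number 6 percentage points lower (within the scatter) from compound 3 to compound 4, 6 percentage points apart, within the scatter of two such steps. This shows that on these two cores the swap leaves no step beyond the scatter at the one concentration tested, but it does not show how the change would behave on a third core or at any other concentration.

The compounds shown leave open what a different group at this place, such as an ethoxy group or a carboxylic acid, would do. They also leave open what removing a methoxy group from another place would do.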